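The source may report more compounds than this note shows. Statements on the series, on what has been measured and on what is new or still open speak of the compounds shown alone.

In a functional assay on HL-60 cells (Homo sapiens) for antiproliferative activity, with a stated time of 72 h (on this read-out higher numbers stand for weaker inhibition and lower numbers for stronger inhibition), two compounds that share a core have been measured so far. Compound 1 `OC[C@H]1O[C@@H](n2cnc3c(NCc4ccccc4F)ncnc32)[C@H](O)[C@@H]1O` gives 3200 nM, and compound 2 `Cc1cccc(CNc2ncnc3c2ncn3[C@@H]2O[C@H](CO)[C@@H](O)[C@H]2O)c1` gives 6400 nM. Among the measured compounds shown here, compound 2 therefore has only one measured neighbour, and the two values lie within the scatter of each other. The next compound to be tested is compound 3 `OC[C@H]1O[C@@H](n2cnc3c(NCc4ccc(Cl)cc4Cl)ncnc32)[C@H](O)[C@@H]1O`. It differs from compound 2 as follows: 2,4-dichlorophenyl in place of 3-methylphenyl on a saturated chain carbon bound to a nitrogen on an aromatic ring. In words, 2,4-dichlorophenyl stands in place of 3-methylphenyl on a saturated chain carbon bound to a nitrogen on an aromatic ring.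

For the measured compounds named here, only one measured step bears on this change. It is a 2.0-fold higher number from compound 1 to compound 2 (0.30 log units; within the scatter), which involves the same place and stays within the scatter. Going by the values given here, no measured compound carries chlorine, so the data offer no direct guide to this group, and one small step is thin evidence. No change beyond the scatter is therefore anticipated in this assay, and no firm direction can be given. The expected step is a 1.6-fold lower number from compound 2 to compound 3 (0.20 log units; within the scatter). For compound 3, the estimated value is 4000 nM, with an expected range of 1500 nM to 10000 nM.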

Compound 3, half-maximal inhibitory concentration: 96300 nM
For compound 3 the middle estimate is 24-fold (1.38 log units) below the measured one, and the stated range ends below it.
By their numbers in this assay, from the lowest: compounds 1 and 2 (each within the scatter of the next); then compound 3.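

In this assay, this position proves sensitive to the choice of aryl group, which the earlier pair could not show, as a 2.0-fold higher number from compound 1 to compound 2 (0.30 log units; within the scatter) had stayed within the scatter. Placing 2,4-dichlorophenyl on the saturated chain carbon in place of 3-methylphenyl gives a 15-fold higher number from compound 2 to compound 3 (1.18 log units; beyond the scatter), and placing it there in place of 2-fluorophenyl gives a 30-fold higher number from compound 1 to compound 3 (1.48 log units; beyond the scatter), so compound 3 is the weakest of the three and both changes point the same way. No measurement shown here accounts for this loss of activity, so its cause remains unknown.

The compounds shown leave open whether the loss follows from the two chlorine atoms together or whether a phenyl ring bearing a single chlorine would already produce it. They also do not tell how a ring carrying an amine or a carboxylic acid, or a longer chain between the ring and the nitrogen, would fare at this position.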